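Swapping tert-butylphenyl for naphthyl in a cytotoxic series

The compounds below may be only part of what the source reports. "The series", "measured", "known", "first", "only" and "open" are said of these compounds alone.

- compound 1 `C=C(c1ccc(OC)cc1)c1cc(OC)c(OC)c(OC)c1-c1ccc(OC)cc1`: 37000 nM
- compound 2 `C=C(c1ccc(OC)cc1)c1cc(OC)c(OC)c(OC)c1-c1ccccc1`: 8000 nM
- compound 3 `C=C(c1ccc(OC)cc1)c1cc(OC)c(OC)c(OC)c1-c1ccc(C(C)(C)C)cc1`: 39000 nM

In a functional assay on DU-145 cells (Homo sapiens) for cytotoxicity, read by MTT assay, with a stated time of 48 h (on this read-out higher numbers stand for weaker inhibition and lower numbers for stronger inhibition), compound 3 gives 39000 nM, and it cannot be told apart from compound 1: the data show a 1.1-fold higher number from compound 1 to compound 3 (0.02 log units; within the scatter). Only compound 2 stands clearly apart from these two.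

The next compound, compound 4 `C=C(c1ccc(OC)cc1)c1cc(OC)c(OC)c(OC)c1-c1ccc2ccccc2c1`, changes the same aromatic carbon of the shared core, with naphthalen-2-yl in place of 4-(tert-butyl)phenyl on an aromatic carbon.

Three measured steps at this position bear on the change. Two are modest, a 4.6-fold lower number from compound 1 to compound 2 (0.67 log units; beyond the scatter) and a 4.9-fold higher number from compound 2 to compound 3 (0.69 log units; beyond the scatter), and the third, a 1.1-fold higher number from compound 1 to compound 3 (0.02 log units; within the scatter), is within the scatter. Changes here have so far moved the number only modestly, and none of the three compounds carries a naphthalen-2-yl group, so the direction is uncertain. A small move towards the lower numbers is expected, as the estimated 2.0-fold lower number from compound 3 to compound 4 (0.29 log units; within the scatter), and it may not clear the scatter. The estimate for compound 4 is 20000 nM, with an expected range from 7000 nM to 45000 nM.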

Compound 4, half-maximal inhibitory concentration: 46000 nM
Beside the measured number, compound 4's estimate is 2.3-fold (0.36 log units) below it; the measured number lies above the stated range.
By their numbers in this assay, from the lowest: compound 2; then compounds 1, 3 and 4 (each within the scatter of the next).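

In this assay, putting the two aromatic rings of naphthalen-2-yl in place of the single ring of 4-(tert-butyl)phenyl gives a 1.2-fold higher number from compound 3 to compound 4 (0.07 log units; within the scatter), and swapping in the same group for 4-methoxyphenyl gives a 1.2-fold higher number from compound 1 to compound 4 (0.09 log units; within the scatter), so compound 4 cannot be told apart from compound 1 or compound 3. Against the plain phenyl group the change gives a 5.8-fold higher number from compound 2 to compound 4 (0.76 log units; beyond the scatter), which leaves compound 2 as the only one of the four that stands apart, while the 4-methoxyphenyl, 4-(tert-butyl)phenyl and naphthalen-2-yl groups sit together at higher numbers. No supporting measurement is available to explain why these three groups behave alike.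

As far as these compounds go, it remains open whether a phenyl ring carrying a fluorine, a hydroxyl or an amine would stay close to compound 2 or join the other three. A heteroaromatic ring such as pyridine at this position is also untested by the compounds shown here.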